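A few compounds are considered here, and "the series" means these few. Any claim that something is new, unique, unknown or untested is made for them only; others in the source may bear on it.

Of the compounds shown here, two have been tested in an ADME assay on HEK-293T cells (Homo sapiens) for cytotoxicity, read by MTT assay, with a stated time of 24 h; on this read-out lower numbers stand for higher toxicity in this test and higher numbers for lower toxicity in this test. Compound 1, with the structure `Cc1cncc(C(=O)n2c(-c3cn(-c4ccccc4)nc3-c3ccc(C(F)(F)F)cc3)nc3ccccc32)c1`, gives 123000 nM. Compound 2, with the structure `Cc1ccc(C(=O)n2c(-c3cn(-c4ccccc4)nc3-c3ccc(F)cc3)nc3ccccc32)cc1`, gives 178000 nM in this assay. Compound 2 has the highest of these two numbers, but the nearest one, that of compound 1, lies within the usual scatter of repeated measurements, so the two numbers cannot be told apart.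

Compound 3, with the structure `Cc1cncc(C(=O)n2c(-c3cn(-c4ccccc4)nc3-c3ccc(F)cc3)nc3ccccc32)c1`, has not yet been measured. It differs from compound 2 in one place: 5-methylpyridin-3-yl in place of 4-methylphenyl on a carbonyl carbon. For the measured compounds named here, no pair of measured compounds shares this single change, so no measured step shows what it does here. Compound 1 already carries a 5-methylpyridin-3-yl on its carbonyl carbon, and its number in this assay sits within the scatter of that of compound 2, which gives no sign of a shift. The step expected from the change is a 1.2-fold lower number from compound 2 to compound 3 (0.07 log units; within the scatter), none beyond the scatter. For compound 3 in this assay the estimate is 150000 nM, with a range from 70000 nM to 320000 nM.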

Compound 3, half-maximal cytotoxic concentration: 119000 nM
For compound 3 the middle estimate is 1.3-fold (0.10 log units) above the measured one, and the stated range covers the measured number.
By their numbers in this assay, from the lowest: compounds 3, 1 and 2 (each within the scatter of the next).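

The change from 4-methylphenyl to 5-methylpyridin-3-yl on the carbonyl carbon now has a measured size in this assay: it is a 1.5-fold lower number from compound 2 to compound 3 (0.17 log units; within the scatter), so in this pair, putting a ring nitrogen and a hydrogen-bond acceptor into this group gives no shift that can be told apart from repeat-measurement noise. For the compounds shown here, compound 3 also gives the first measured step for fluoro in place of trifluoromethyl on an aromatic carbon, a 1.0-fold lower number from compound 1 to compound 3 (0.01 log units; within the scatter), and this change likewise shows no readable shift with 5-methylpyridin-3-yl on the carbonyl carbon. No measurement at hand bears on why these numbers fall as they do.

Going by these compounds, both groups compared on the carbonyl carbon are methyl-bearing six-membered aromatic rings, so it remains open whether a very different group there, such as a carboxylic acid or an amine, would move the number beyond the scatter. The same question stands for the aromatic carbon that holds fluoro or trifluoromethyl, where a methoxy group or a longer chain could be compared, and each of these two changes rests on a single pair of compounds.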